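Dropping One Methyl from the Core of Compound 1

This account rests on a few compounds, and the source may have more. Where it says the series, first, only, none or still open, it means among the compounds named here.

Compound 1 `CC1(C)C(=O)c2[nH]ncc2C(C2CC2)N1S(=O)(=O)c1ccc(C(F)(F)F)cc1` is the better of the two measured compounds: in an ADME assay on microsomes from liver (Homo sapiens) for metabolic stability, using NADPH, with a stated time of 30 min, tested at 1 uM, in the presence of a further agent that is not named here (a lower number here means that less of the compound is left, a higher number that more of the compound is left), compound 1 gives 68%, while compound 2 `CC(C)[C@H]1C(=O)c2[nH]ncc2[C@@H](C(C)C)N1S(=O)(=O)c1ccc(C(F)(F)F)cc1` gives 0% in this assay, a gap well beyond the scatter. Compound 2 differs from compound 1 in more than one place, so nothing is known about the effect of any single change from the pair. Compound 3 `CC1C(=O)c2[nH]ncc2C(C2CC2)N1S(=O)(=O)c1ccc(C(F)(F)F)cc1` is compound 1 with hydrogen in place of methyl on a saturated ring carbon. Among the compounds with values here, no measured pair shows this change, so the size of the step is open. The account expects a small to moderate downward step from compound 1 to compound 3 in this assay, of a number 18 percentage points lower from compound 1 to compound 3 (beyond the scatter), because compound 1 already stands at 68% and a change at the same ring carbon in compound 2 went with a much lower number. Compound 3 is therefore estimated at 50%, with a range from 25% to 75%.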

Compound 3, percent of the compound remaining: 62%
Beside the measured number, compound 3's estimate is 12 percentage points below it; the range from low to high includes it.
By their numbers in this assay, from the lowest: compound 2; then compounds 3 and 1 (each within the scatter of the next).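

In this assay, hydrogen in place of methyl on a saturated ring carbon, next to the ring nitrogen, gives a number 6 percentage points lower from compound 1 to compound 3 (within the scatter). Within the data shown here, this is the first single-place step, and it shows that removing one of the two methyl groups on this carbon leaves the percentage of compound remaining within the usual scatter, so compound 1 and compound 3 cannot be ranked in this assay. Nothing available explains why the read-out holds at this position.

The compounds shown leave open how the read-out would respond if this ring carbon carried hydrogen in place of both methyl groups, or an ethyl group or a hydroxymethyl group in place of the methyl that left. They also leave open whether a different group on the ring atom that bears the cyclopropyl group would change the number.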